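The source may hold more compounds than are shown below. What is called first, only, known or untested is meant among the compounds shown, and "the series" means these compounds.

Three compounds of the series share one core and differ only in the group on the aromatic carbon. Compound 1 `C=CC(=O)Nc1cc(C(F)(F)F)cc(C(F)(F)F)c1` carries a (vinylcarbonyl)amino group and in an ADME assay for pharmacokinetics, read by LC-MS, in phosphate buffer, with a stated time of 72 h, at pH 7.4, tested at 250 uM (on this read-out lower numbers stand for a shorter-lived compound and higher numbers for a longer-lived compound), compound 1 gives 1.8 h. Compound 2 `C=CC(=O)Oc1cc(C(F)(F)F)cc(C(F)(F)F)c1` carries a (vinylcarbonyl)oxy group in its place and gives < 0.017 h, which is a limit of this assay and not a number. Compound 3 `O=C1C=CC(=O)N1c1cc(C(F)(F)F)cc(C(F)(F)F)c1` carries the five-membered non-aromatic ring and gives < 0.017 h, again a limit of this assay. Compound 3 thus stands at the lowest reported end of the series, together with one other value (the limit of < 0.017 h in this assay, at which 2 of the 3 values shown sit), and the steps of an at least 100-fold lower number from compound 1 to compound 2 (2.02 log units; beyond the scatter) and an at least 100-fold lower number from compound 1 to compound 3 (2.02 log units; beyond the scatter) are both beyond the scatter, while a step that the two limits leave unreadable from compound 2 to compound 3.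

Compound 4 `C=Cc1cc(C(F)(F)F)cc(C(F)(F)F)c1` is the next member: a group of 2 heavy atoms (2 carbon; no ring) in place of a group of 7 heavy atoms (4 carbon, 1 nitrogen, 2 oxygen; one five-membered non-aromatic ring with 1 hetero atom), on an aromatic carbon. Going by the values given here, only the step from compound 1 to compound 3 bears on this change, and it is large; no measured pair separates the role of the vinyl from that of the carbonyl-bearing groups, so the size of the return is not read from the data. The expected step is an at least 1400-fold higher number from compound 3 to compound 4 (3.14 log units; beyond the scatter), towards a longer-lived compound. For compound 4 the estimated half-life is 24 h, with a range from 1.5 h to 72 h.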

Compound 4, half-life: > 50 h
Compound 4: no number, only a limit; the forecaster's own chance of this, stated with the estimate: 30%; middle value at least 2.0-fold (0.31 log units) from the limit.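

In this assay compound 4 gives > 50 h, a limit and not a number, and the series now has a member at its upper end as well as its lower end: the limit of > 50 h in this assay, at which 1 of the 4 values shown sits.

With vinyl on the aromatic carbon, meta to two trifluoromethyl groups, the half-life is separated from both compounds at the lower limit, in the steps of an at least 2900-fold higher number from compound 3 to compound 4 (3.46 log units; beyond the scatter) and an at least 2900-fold higher number from compound 2 to compound 4 (3.46 log units; beyond the scatter). Going by these compounds alone, the step of an at least 27-fold higher number from compound 1 to compound 4 (1.44 log units; beyond the scatter) adds what the earlier compounds could not show: compound 1, which had stood only at the top of the series, now lies in the middle, and all three groups bearing a carbonyl on this aromatic carbon give a shorter half-life than vinyl.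

All three new steps rest on limits, so their full sizes stay unknown, and no pair shown tells whether the step follows the carbonyl, the amino or oxy link, or the second double bond. Also open, from the compounds shown here alone, is where an ethyl group, a saturated propanoylamino group or a simple amine on the same aromatic carbon would fall on this read-out.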